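This account rests on a few compounds, and the source may have more. Where it says the series, first, only, none or still open, it means among the compounds named here.

Compound 1 `CS(=O)(=O)c1ccc(-c2cnc3[nH]cc(-c4nnc(-c5ccc(F)cc5)o4)c(=O)c3c2)cc1` gives 3.11% in a functional assay on A549 cells (Homo sapiens) for inhibition, read by MTT assay, with a stated time of 24 h, tested at 5 uM; on this read-out higher numbers stand for more inhibition of growth at the one concentration tested and lower numbers for less inhibition of growth.
Compound 2 `CS(=O)(=O)c1ccc(-c2cnc3[nH]cc(-c4nnc(-c5ccc(Cl)cc5)o4)c(=O)c3c2)cc1` gives 23.8% in this assay.
Compound 3 `Cc1ccc(-c2nnc(-c3c[nH]c4ncc(-c5ccc(S(C)(=O)=O)cc5)cc4c3=O)o2)cc1` gives 6.69% in this assay.

Of these three, compound 2 stands highest in this assay: the step of a number 20.7 percentage points higher from compound 1 to compound 2 (beyond the scatter) and the step of a number 17.1 percentage points lower from compound 2 to compound 3 (beyond the scatter) both lie beyond the scatter, whereas the step of a number 3.6 percentage points higher from compound 1 to compound 3 (within the scatter) does not. All three differ only in the group on the phenyl ring attached to the oxadiazole, while the methylsulfonylphenyl group is shared.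

Compound 4 `N#Cc1ccc(-c2cnc3[nH]cc(-c4nnc(-c5ccc(Cl)cc5)o4)c(=O)c3c2)cc1` keeps the chloro of compound 2 and instead alters the shared side: cyano in place of methylsulfonyl on an aromatic carbon. Within the data shown here, none of the measured steps touches this group, so no measured step bears directly on the change; the three values show only what swapping fluoro, chloro and methyl on the other ring does. With nothing to anchor it, the expectation for compound 4 rests on compound 2 alone and carries a wide range. Compound 4 is expected to give about 18%, somewhere between 0% and 45%. The step of a number 5.8 percentage points lower from compound 2 to compound 4 (within the scatter) is therefore expected to fall within the scatter, though this is a guess rather than a trend.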

Compound 4, percent growth inhibition at one concentration: 7.6%
The estimate for compound 4 lay 10.4 percentage points above the measured number; the measured number falls inside the stated range.
By their numbers in this assay, from the lowest: compounds 1, 3 and 4 (each within the scatter of the next); then compound 2.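

Keeping the chloro of compound 2 and placing cyano in the methylsulfonyl position gives a number a number 16.2 percentage points lower from compound 2 to compound 4 (beyond the scatter) in this assay. Among these compounds, this is the first sign that the group on this shared ring, para to a large group, also affects growth inhibition, and not only the group on the phenyl ring attached to the oxadiazole. Nothing available explains this step.

From the compounds shown here alone, only the chloro pair shows this change, so it remains open whether cyano would also lower the number with fluoro or methyl on the other ring. The compounds shown also leave open how an amine, a carboxylic acid or a methoxy group at this place on the shared ring would read in this assay.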